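The source may report more compounds than this note shows. Statements on the series, on what has been measured and on what is new or still open speak of the compounds shown alone.

Measured in a functional assay on V79 cells (Cricetulus griseus) for cytotoxicity, read by colony formation; a lower number here means a stronger inhibitor, a higher number a weaker inhibitor:
- Compound 1 `CCNCC1CCN(c2c(F)cc3c(=O)c(C(=O)O)cn(C4CC4)c3c2Cl)C1`: 11 ug/mL; 11 ug/mL; < 11 ug/mL (3 entries)
- Compound 2 `O=C(O)c1cn(C2CC2)c2c(Cl)c(N3CCNCC3)c(F)cc2c1=O`: 43 ug/mL
- Compound 3 `CC1CN(c2cc3c(cc2F)c(=O)c(C(=O)O)cn3C2CC2)CC(C)N1`: > 500 ug/mL

Compound 3 gives only a limit, > 500 ug/mL, and no single number. Compound 4 `CC1CN(c2c(F)cc3c(=O)c(C(=O)O)cn(C4CC4)c3c2Cl)CC(C)N1` has chloro in place of hydrogen on an aromatic carbon, ortho to the 3,5-dimethylpiperazin-1-yl group: chloro in place of hydrogen on an aromatic carbon. Going by the values given here, no measured pair shows this change alone. Compound 2 carries the same chloro and gives 43 ug/mL. Compound 1 also carries it and gives 11 ug/mL; 11 ug/mL; < 11 ug/mL (3 entries). A large step towards stronger inhibition in this assay, beyond the scatter, is therefore expected for an at least 10-fold lower number from compound 3 to compound 4 (1.00 log units; beyond the scatter). The expected value for compound 4 is 50 ug/mL, with an estimated range of 15 ug/mL to 200 ug/mL.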

Compound 4, half-maximal inhibitory concentration: 140 ug/mL
The estimate for compound 4 lay 2.8-fold (0.45 log units) below the measured number, and the stated range covers the measured number.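

In this assay, chloro in place of hydrogen on an aromatic carbon, ortho to the 3,5-dimethylpiperazin-1-yl group, now has a step of its own: an at least 3.5-fold lower number from compound 3 to compound 4 (0.55 log units; beyond the scatter). The size of that step is only a lower bound, since compound 3 gives a limit and not a number: the limit of > 500 ug/mL in this assay, at which 1 of the 4 values shown sits. With the chloro held in place, 3,5-dimethylpiperazin-1-yl in place of piperazin-1-yl gives a 3.3-fold higher number from compound 2 to compound 4 (0.51 log units; beyond the scatter), so the group on the neighbouring aromatic carbon also moves the number.

On these data alone, the full size of the chloro step remains open, as does whether it carries over to the groups of compound 1 or compound 2. As far as these compounds go, how a methoxy or bromo group would read at this aromatic carbon also stays open.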